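A few compounds are considered here, and "the series" means these few. Any claim that something is new, unique, unknown or untested is made for them only; others in the source may bear on it.

Of the compounds shown here, three built on one shared core have been tested in a functional assay on HeLa cells (Homo sapiens) for antiproliferative activity, read by CCK-8 assay, with a stated time of 72 h, tested at 8 uM; a lower number here means a weaker effect, a higher number a stronger effect of the compound at the concentration tested. Compound 1 `COc1ccc(N2CCN(C(=S)SCc3ccc(C(=O)Nc4ccccc4N)cc3)CC2)cc1` gives 52.3% and stands second highest of the three. Compound 3 `Nc1ccccc1NC(=O)c1ccc(CSC(=S)N2CCc3cc(Cl)ccc32)cc1` gives 65.1%, while compound 2 `Nc1ccccc1NC(=O)c1ccc(CSC(=S)N2CCCc3ccccc32)cc1` gives 35.7%. Among the compounds with values here, the only step between two compounds that differ in a single place is a number 29.4 percentage points higher from compound 2 to compound 3 (beyond the scatter); it concerns the group on the thiocarbonyl carbon.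

Compound 4 `Nc1ccccc1NC(=O)c1ccc(CSC(=S)N2CCN(c3ncccn3)CC2)cc1` differs from compound 1 by pyrimidin-2-yl in place of 4-methoxyphenyl on an amine nitrogen in a ring. Within the data shown here, this change sits on the amine nitrogen in a ring, a different place from the one varied between compound 2 and compound 3, so no measured step speaks directly to it. The values of compound 1, compound 2 and compound 3 show that changes at the far end of the molecule can move this assay by a modest amount, but they give no direction for the present swap. Compound 4 is therefore expected to land close to compound 1, with a step of a number 4.3 percentage points lower from compound 1 to compound 4 (within the scatter) that is estimated to stay within the scatter. The estimate for compound 4 is 48%, with a range from 30% to 66%.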

Compound 4, a percentage reported as inhibition, at one concentration (the size of the read-out at that concentration, not a potency): 73.9%
Compound 4: middle estimate off by 25.9 percentage points, on the low side, and the stated range ends below it.
By their numbers in this assay, from the lowest: compound 2; then compound 1; then compounds 3 and 4 (each within the scatter of the next).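

In this assay, the aryl ring on the amine nitrogen proves able to move the read-out by itself: pyrimidin-2-yl in place of 4-methoxyphenyl gives a number 21.6 percentage points higher from compound 1 to compound 4 (beyond the scatter). The earlier step exchanged the whole group on the thiocarbonyl carbon, whereas this one keeps the six-membered ring with two nitrogens and changes only what that ring carries, so this position counts in its own right. Nothing measured here accounts for the size of the step.

This single swap changes several things at once: the methoxy group leaves, the ring gains two nitrogens, and the group goes from 8 to 6 heavy atoms. Plain phenyl or pyridin-2-yl on the same nitrogen would help to tell which of these changes goes with the higher number.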